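The compounds below may be only part of what the source reports. "The series", "measured", "known", "first", "only" and "open" are said of these compounds alone.

Measured so far:
- compound 1 `CS(=O)(=O)c1ccc(-c2cnc3[nH]cc(-c4nnc(-c5ccc(Cl)cc5)o4)c(=O)c3c2)cc1`: 9.3%
- compound 2 `N#Cc1ccc(-c2cnc3[nH]cc(-c4nnc(-c5ccc(Cl)cc5)o4)c(=O)c3c2)cc1`: 9.73%

For the measured compounds named here, in a functional assay on KB cells (Homo sapiens) for inhibition, read by MTT assay, with a stated time of 24 h, tested at 10 uM (on this read-out lower numbers stand for less inhibition of growth and higher numbers for more inhibition of growth at the one concentration tested), compound 2 gives 9.73%, a number that stands within the scatter of compound 1; the only measured step, a number 0.4 percentage points higher from compound 1 to compound 2 (within the scatter), showed no change beyond scatter. Compound 3 `O=c1c(-c2nnc(-c3ccc(Cl)cc3)o2)c[nH]c2ncc(-c3ccccc3)cc12` differs by hydrogen in place of cyano on an aromatic carbon. Going by the values given here, no measured step removes the group at that position altogether, so the one step on record bears on it only loosely, and both measured compounds sit low in this assay. Compound 3 is therefore expected to remain near the same low level, a number 1.7 percentage points lower from compound 2 to compound 3 (within the scatter), with an estimate of 8% and a range from 0% to 20%.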

Compound 3, percent growth inhibition at one concentration: 19.5%
The estimate for compound 3 lay 11.5 percentage points below the measured number; measured number inside the range.
By their numbers in this assay, from the lowest: compounds 1, 2 and 3 (each within the scatter of the next, the first and the last beyond it).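

In this assay, for the compounds shown here, the change to hydrogen gives a number 10.2 percentage points higher from compound 1 to compound 3 (beyond the scatter) and is the first step to pass the scatter, while 4-cyanophenyl to phenyl reads a number 9.8 percentage points higher from compound 2 to compound 3 (within the scatter) and stays within it. A substituent on this carbon is therefore not needed for the growth inhibition seen so far, and the plain phenyl separates only from the methylsulfonyl compound. No evidence on record bears on the reason for this step.

Still open, on these data alone, is how an amine, a hydroxyl or a fluorine on this carbon would read. The compounds shown also leave open whether any group there would separate from hydrogen.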